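A few compounds are considered here, and "the series" means these few. Any claim that something is new, unique, unknown or untested is made for them only; others in the source may bear on it.

Values in an ADME assay on cells (Erythrocyte, Homo sapiens), read by spectrophotometry and hemolysis, with a stated time of 1 h (a lower number here means that less compound is needed, a higher number that more compound is needed for the effect), for three compounds:
compound 1 `O=[N+]([O-])c1cccc(-c2csc(N/N=C/c3ccc(C(F)(F)F)cc3)n2)c1` gives > 250 ug/mL as a limit
compound 2 `FC(F)(F)c1ccc(/C=N/Nc2nc(-c3ccc(Cl)cc3Cl)cs2)cc1` gives > 250 ug/mL as a limit
compound 3 `COc1ccc(-c2csc(N/N=C/c3ccc(C(F)(F)F)cc3)n2)cc1` gives > 250 ug/mL as a limit

Compound 2 reads > 250 ug/mL here, a limit and not a number, and it shares that position with the other two, as the limit of > 250 ug/mL in this assay, at which 3 of the 3 values shown sit, shows. Compound 4 `FC(F)(F)c1ccc(/C=N/Nc2nc(-c3ccc(Cl)c(Cl)c3)cs2)cc1` has the same atoms joined differently, and 3,4-dichlorophenyl in place of 2,4-dichlorophenyl on an aromatic carbon is the whole change, 3,4-dichlorophenyl in place of 2,4-dichlorophenyl on an aromatic carbon. Going by the values given here, the steps that bear on this are a step that the two limits leave unreadable from compound 1 to compound 2 and a step that the two limits leave unreadable from compound 2 to compound 3 and neither gives a size. In this assay the expected step is a number no higher from compound 2 to compound 4 (the limit leaves the size open) and nothing beyond the scatter is expected in either direction. Compound 4 is estimated as 250 ug/mL with an expected range from 120 ug/mL to 500 ug/mL and will most likely be reported as a limit too.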

Compound 4, half-maximal effective concentration: > 250 ug/mL
Compound 4: a limit, no number; the forecaster's own chance of this, stated with the estimate: 85%; the middle value sits exactly at the limit.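

In this assay compound 4 gives only a limit, as do compound 1, compound 2 and compound 3, so no step among them can be read: the limit of > 250 ug/mL in this assay, at which 4 of the 4 values shown sit.

The compounds shown leave open how far any of the four lies past that limit, and so whether the group changed on the shared core affects this read-out at all.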